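Naphthalen-1-yl in Place of 3-Methylphenyl: Expected Inhibition

The compounds below may be only part of what the source reports. "The series", "measured", "known", "first", "only" and "open" are said of these compounds alone.

Measured so far:
In a functional assay on SF-268 cells (Homo sapiens) for inhibition, read by sulforhodamine B assay, with a stated time of 48 h, tested at 10 uM (on this read-out higher numbers stand for more inhibition at the one concentration tested (going by the name of the read-out) and lower numbers for less inhibition), compound 1, `Brc1cn2ccnc2c(-c2ccc3ncn(C4CCCCC4)c3c2)n1`, gives 17.1%.
In this assay compound 2, `c1ccc2c(-c3cn4ccnc4c(-c4ccc5ncn(C6CCCCC6)c5c4)n3)cccc2c1`, gives 7.84%.
In this assay compound 3, `Cc1cccc(-c2cn3ccnc3c(-c3ccc4ncn(Cc5ccccc5)c4c3)n2)c1`, gives 7.22%.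

Compound 3 holds the smallest of the three figures, yet compound 1 and compound 2 both lie within the usual scatter of it, so no ranking can be read from these numbers. Compound 4, `c1ccc(Cn2cnc3ccc(-c4nc(-c5cccc6ccccc56)cn5ccnc45)cc32)cc1`, differs from compound 3 in one place: naphthalen-1-yl in place of 3-methylphenyl on an aromatic carbon. Within the data shown here, one measured step bears on this, since it brings in the same naphthalen-1-yl group, though in place of bromo rather than 3-methylphenyl: a number 9.3 percentage points lower from compound 1 to compound 2 (within the scatter). That step stayed within the scatter, and compound 2 and compound 3, which already carry naphthalen-1-yl and 3-methylphenyl, gave values within the scatter of each other. Compound 4 is therefore expected to show no step beyond the scatter, a number 0.2 percentage points lower from compound 3 to compound 4 (within the scatter). The estimate for compound 4 in this assay is 7%, with a range from -4% to 18%.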

Compound 4, a percentage reported as inhibition, at one concentration (the size of the read-out at that concentration, not a potency): 10.3%
Compound 4: middle estimate off by 3.3 percentage points, on the low side; low and high end bracket the measured number.
By their numbers in this assay, from the lowest: compounds 3, 2, 4 and 1 (each within the scatter of the next).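

At this position on the shared core, the direct exchange in this assay gives a number 3.1 percentage points higher from compound 3 to compound 4 (within the scatter), so the added ring of naphthalen-1-yl leaves the change from 3-methylphenyl within the scatter. Among these compounds, the exchange on the aromatic nitrogen, read here for the first time, gives a number 2.5 percentage points higher from compound 2 to compound 4 (within the scatter), also within the scatter. Nothing available explains either step.

Open, going by these compounds, is whether an amine or a carboxylic acid on the aromatic carbon would move the number beyond the scatter. Equally open, on these data alone, is what a longer chain in place of benzyl on the nitrogen would do.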